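Cytotoxicity limits across the biaryl amide series

The compounds below may be only part of what the source reports. "The series", "measured", "known", "first", "only" and "open" are said of these compounds alone.

Compound 2 `CC(C)N(Cc1cccc(OCCCCCC(=O)O)c1)C(=O)c1ccccc1` is the parent of this set. In an ADME assay on Raji cells (Homo sapiens) for cytotoxicity, read by CellTiter-Glo and resazurin assay, with a stated time of 72 h (on this read-out lower numbers stand for an effect already at smaller amounts and higher numbers for an effect only at larger amounts of compound), compound 2 gives > 26000 nM, a limit of the assay rather than a number. Compound 1 `CC(C)N(Cc1cccc(OCCCCCC(=O)O)c1)C(=O)c1ccc(-c2cccc(N(C)C)c2)cc1` carries a 3-(dimethylamino)phenyl group on an aromatic carbon of that core. In this assay compound 1 gives > 26000 nM, again only a limit. Compound 3 `CC(C)N(Cc1cccc(OCCCCCC(=O)O)c1)C(=O)c1ccc(-c2cccc(-c3ccccc3)c2)cc1` carries a 3-phenylphenyl group at the same position. In this assay compound 3 gives > 26000 nM, also a limit. All three values sit at the limit (the limit of > 26000 nM in this assay, at which 3 of the 3 values shown sit), so none of the steps can be read: a step that the two limits leave unreadable from compound 1 to compound 2, a step that the two limits leave unreadable from compound 1 to compound 3 and a step that the two limits leave unreadable from compound 2 to compound 3 are all unreadable in size.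

Compound 4 `CCOc1cccc(-c2ccc(C(=O)N(Cc3cccc(OCCCCCC(=O)O)c3)C(C)C)cc2)c1` is the next member. It differs from compound 2 by 3-ethoxyphenyl in place of hydrogen on an aromatic carbon. The step that bears on it most directly is the one from hydrogen to 3-phenylphenyl, a step that the two limits leave unreadable from compound 2 to compound 3, which the limits leave without a size. Since compound 2 and compound 3 both stop at the limit, the expectation for compound 4 is that this assay again reports no effect within the tested range, with an expected step that the limit leaves unreadable from compound 2 to compound 4. The estimate for compound 4 in this assay is 30000 nM, between 15000 nM and 60000 nM.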

Compound 4, half-maximal effective concentration: > 20800 nM
Compound 4: no number, only a limit; the forecaster's own chance of this, stated with the estimate: 85%; the middle value does not contradict the limit.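

In this assay compound 4 gives > 20800 nM, which is a limit and not a number. With only limits on both sides, none of the steps linking compound 4 to compound 1, compound 2 or compound 3 can be read. The compounds shown leave open whether any group at this position gives a measurable effect in this assay.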